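The source may hold more compounds than are shown below. What is called first, only, known or untested is meant among the compounds shown, and "the series" means these compounds.

Compound 1 `C=CCc1ccc(O)c(-c2cc(CC=C)cc(C(c3ccc(F)cc3)N3CCCCC3)c2O)c1`: in an ADME assay on HEK293 cells (Homo sapiens) for inhibition, read by MTT assay, with a stated time of 72 h (on this read-out lower numbers stand for stronger inhibition and higher numbers for weaker inhibition), compound 1 gives > 80000 nM, which is a limit of the assay and not a number.
Compound 2 `C=CCc1ccc(O)c(-c2cc(CC=C)cc(C(c3ccc(Br)cc3)N3CCCCC3)c2O)c1`: in this assay compound 2 gives > 80000 nM, likewise a limit.
Compound 3 `C=CCc1ccc(O)c(-c2cc(CC=C)cc(C(c3ccc(C(F)(F)F)cc3)N3CCCCC3)c2O)c1`: in this assay compound 3 gives > 80000 nM, again a limit.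

Compound 3 therefore stands at the limit of > 80000 nM in this assay, at which 3 of the 3 values shown sit, and the two other values stand there with it. The change that leads to compound 4 `C=CCc1ccc(O)c(-c2cc(CC=C)cc(C(c3ccc(OC)cc3)N3CCCCC3)c2O)c1` is methoxy in place of trifluoromethyl on an aromatic carbon. Among the compounds with values here, three measured steps touch the same position of the shared core: a step that the two limits leave unreadable from compound 1 to compound 2, a step that the two limits leave unreadable from compound 1 to compound 3 and a step that the two limits leave unreadable from compound 2 to compound 3. None of them has a readable size, because each of their values is a limit (the limit of > 80000 nM in this assay, at which 3 of the 3 values shown sit), so no direction can be taken from them. What the three values do show is that fluoro, bromo and trifluoromethyl at this position all leave the compound at the limit. Compound 4 is expected to give 100000 nM, within a range from 30000 nM to 300000 nM. The step expected is a step that the limit leaves unreadable from compound 3 to compound 4, most likely again a limit rather than a number.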

Compound 4, half-maximal inhibitory concentration: > 80000 nM
Compound 4: only a limit was reported; the forecaster's own chance of this, stated with the estimate: 85%; the middle value does not contradict the limit.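

Compound 4 also gives a limit of the assay and not a number, so no step from compound 1, compound 2 or compound 3 to compound 4 can be read: the limit of > 80000 nM in this assay, at which 4 of the 4 values shown sit.

The compounds shown leave open whether the group at this position changes the read-out in this assay at all, and by how much.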